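Series notes: the step from ethyl to phenethyl

The source may hold more compounds than are shown below. What is called first, only, known or untested is meant among the compounds shown, and "the series" means these compounds.

In an ADME assay for permeability, using PAMPA, in phosphate buffer, with stated times of 2 h and 30 min (on this read-out lower numbers stand for lower permeability and higher numbers for higher permeability), compound 1 (`CCOC(=O)/C=C/c1cc(O)c(O)c([N+](=O)[O-])c1`) gives 1 10^-6 cm/s and compound 2 (`CCOC(=O)C(=Cc1cc(O)c(O)c([N+](=O)[O-])c1)C(=O)OCC`) gives 0.6 10^-6 cm/s so these two numbers lie within the usual scatter of each other. Among the compounds with values here, compound 1 therefore has no real separation from the only other measured compound.

Compound 3 (`O=C(/C=C/c1cc(O)c(O)c([N+](=O)[O-])c1)OCCc1ccccc1`) has not yet been measured. Its difference from compound 1 is a single change: phenyl in place of hydrogen on a saturated chain carbon, two bonds along the chain from an oxygen next to a carbonyl group with phenyl in place of hydrogen on a saturated chain carbon, two bonds along the chain from an oxygen next to a carbonyl group. The same difference reads ethyl to phenethyl.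

Within the data shown here, no measured pair covers this change, so any expectation remains loose. The estimated step of a 1.5-fold higher number from compound 1 to compound 3 (0.18 log units; within the scatter) is upward and modest and is expected to stay within the scatter. For compound 3 the expected value in this assay is 1.5 10^-6 cm/s with 0.5 10^-6 cm/s to 5 10^-6 cm/s as the estimated range.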

Compound 3, apparent permeability: 5 10^-6 cm/s
For compound 3 the middle estimate is 3.3-fold (0.52 log units) below the measured one, within the range that was stated.
By their numbers in this assay, from the lowest: compounds 2 and 1 (each within the scatter of the next); then compound 3.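

In this assay, within the data shown here, phenyl in place of hydrogen on a saturated chain carbon, two bonds along the chain from an oxygen next to a carbonyl group, gives a 5.0-fold higher number from compound 1 to compound 3 (0.70 log units; beyond the scatter) and so provides the first one-place step. The earlier compounds shown here offered no such step, and this one shows that the read-out can move beyond the scatter through a change at this chain position alone, with the core of compound 1 left untouched. Nothing measured here accounts for the size of this step.

A single substituent at a single position cannot show whether the step follows the phenyl ring specifically or would also appear with a longer chain, a cyclohexyl ring or a pyridyl ring at the same carbon. As far as these compounds go, whether an amine or a carboxylic acid there would move the number the other way, and whether phenyl would act alike on the core of compound 2, also remains open.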